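Swapping the benzylic aryl group: methoxy out, chlorine in

A few compounds are considered here, and "the series" means these few. Any claim that something is new, unique, unknown or untested is made for them only; others in the source may bear on it.

Measured compounds:
- compound 1, `COc1ccc(Cc2c(C)[nH]n(-c3nc4ccccc4[nH]3)c2=O)cc1`, gives 630 nM
- compound 2, `Cc1[nH]n(-c2nc3c(C)cccc3[nH]2)c(=O)c1Cc1ccccc1`, gives 5900 nM
- compound 3, `Cc1[nH]n(-c2nc3cc(Cl)ccc3[nH]2)c(=O)c1Cc1ccccc1`, gives 4500 nM

All three numbers come from an assay on isolated protein for inhibition of alpha-ketoglutarate-dependent dioxygenase alkB homolog 3 (Homo sapiens), read by polymerase chain reaction, with a stated time of 1 h; a lower number here means a stronger inhibitor, a higher number a weaker inhibitor. Compound 1 stands at the lowest number of the three. Its nearest neighbour is compound 3, which sits well beyond the scatter above it, and compound 2 lies further out still. Among the measured compounds shown here, compounds 2 and 3 differ from compound 1 in more than one place, so no single step between measured compounds can be read from them; their values show only that compound 1 is the strongest inhibitor among those measured so far.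

Compound 4, `Cc1[nH]n(-c2nc3ccccc3[nH]2)c(=O)c1Cc1ccccc1Cl`, is the next compound in line. It differs from compound 1 in one place: 2-chlorophenyl in place of 4-methoxyphenyl on a saturated chain carbon bound to an aromatic carbon. For the measured compounds named here, no measured pair isolates this change, so the expectation rests on the position of compound 1 alone. With the methoxy-bearing ring gone and a chlorine-bearing ring in its place, a modest loss is expected in this assay, most likely within or just beyond the scatter. Compound 4 is therefore estimated at 1500 nM, with a range from 400 nM to 6000 nM, which corresponds to an expected step of a 2.4-fold higher number from compound 1 to compound 4 (0.38 log units; beyond the scatter).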

Compound 4, half-maximal inhibitory concentration: > 10000 nM
Compound 4: no number, only a limit; the forecaster's own chance of this, stated with the estimate: 5%; middle value at least 6.6-fold (0.82 log units) from the limit.
By their numbers in this assay, from the lowest: compound 1; then compounds 3 and 2 (each within the scatter of the next). At a limit, above all of these: compound 4.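

In this assay compound 4 gives > 10000 nM, which is a limit of the assay and not a number. Even so, the change of 4-methoxyphenyl to 2-chlorophenyl on a saturated chain carbon bound to an aromatic carbon can be read as a single step, which compound 2 and compound 3 could not offer, and it amounts to an at least 15-fold higher number from compound 1 to compound 4 (1.20 log units; beyond the scatter). The group at this place therefore matters greatly to the reading in this assay, and the step is large enough that the group of compound 1 cannot be exchanged here without consequence, at least for this 2-chlorophenyl replacement; the reading for compound 4 ends at a limit: the limit of > 10000 nM in this assay, at which 1 of the 4 values shown sits.

On these data alone, whether the loss follows from the methoxy group leaving, from the chlorine entering, or from the two together stays open, as this one step changes both at once and its full size is unknown. Equally open, as far as these compounds go, is what an amine, a carboxylic acid or a longer chain at this place would give on the core of compound 1.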